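Swapping the benzyl group of compound 2

The source may hold more compounds than are shown below. What is called first, only, known or untested is meant among the compounds shown, and "the series" means these compounds.

Measured in a functional assay on HCT-116 cells (Homo sapiens) for inhibition, read by MTT assay, with a stated time of 72 h; on this read-out higher numbers stand for weaker inhibition and lower numbers for stronger inhibition:
- Compound 1 `O=C1/C(=C\c2ccccc2)c2c(ncn2COCc2ccccc2)CCN1Cc1ccccc1`: 20000 nM
- Compound 2 `O=C1/C(=C\c2ccccc2)c2c(ncn2COCc2ccccc2)CCN1Cc1ccc(F)cc1`: 11200 nM
- Compound 3 `Cc1cc(C)cc(CN2CCc3ncn(COCc4ccccc4)c3/C(=C/c3ccccc3)C2=O)c1`: not yet measured

Among the compounds with values here, only two numbers exist so far. Compound 2, at 11200 nM, lies within the usual scatter of compound 1, so the two cannot be ranked.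

Compound 3 keeps the shared core and alters one group: 3,5-dimethylphenyl in place of 4-fluorophenyl on a saturated chain carbon bound to an amide-type nitrogen in a ring. Put simply, 3,5-dimethylphenyl stands in place of 4-fluorophenyl on a saturated chain carbon bound to an amide-type nitrogen in a ring.

Within the data shown here, one measured step touches this same group, a 1.8-fold lower number from compound 1 to compound 2 (0.25 log units; within the scatter). There, fluoro replaced hydrogen on an aromatic carbon, and the number stayed within the scatter. Among the measured compounds shown here, no measured compound carries methyl groups on this ring, so this single step is thin evidence. Even so, it gives no reason to expect a change beyond the scatter in this assay.

The estimated step is a 1.2-fold higher number from compound 2 to compound 3 (0.06 log units; within the scatter). Compound 3 is expected near 13000 nM, with an estimated range of 6000 nM to 28000 nM.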

Compound 3, half-maximal inhibitory concentration: 6230 nM
The estimate for compound 3 lay 2.1-fold (0.32 log units) above the measured number; low and high end bracket the measured number.
By their numbers in this assay, from the lowest: compounds 3, 2 and 1 (each within the scatter of the next, the first and the last beyond it).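

In this assay, within the data shown here, the step from phenyl to 3,5-dimethylphenyl on a saturated chain carbon bound to an amide-type nitrogen in a ring is a 3.2-fold lower number from compound 1 to compound 3 (0.51 log units; beyond the scatter) and is the first change here to clear the scatter, though only modestly. This shows that altering this aromatic ring can move the number by a measurable amount, which the fluoro step alone could not show. Set against 4-fluorophenyl, the same group gives a 1.8-fold lower number from compound 2 to compound 3 (0.25 log units; within the scatter) and so cannot be ranked against it, and no measurement at hand explains the difference from phenyl.

A single methyl group on this ring might do as much as two or might not, and the compounds shown cannot tell which. Also open, going by these compounds, is what an amine or a carboxylic acid on this ring, or a longer chain in place of the single carbon linking it to the amide-type nitrogen, would do in this assay on this shared core.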